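A few compounds are considered here, and "the series" means these few. Any claim that something is new, unique, unknown or untested is made for them only; others in the source may bear on it.

Measured so far in an assay on BTI-TN-5B1-4 cells for inhibition of Amine oxidase [flavin-containing] B (Homo sapiens), read by fluorescence and Amplex Red, using microsomes, with a stated time of 15 min; on this read-out lower numbers stand for stronger inhibition and higher numbers for weaker inhibition:
Compound 1 `O=C(Nc1ccccc1)OC1CCCN(Cc2ccccc2)C1` gives 33300 nM.
Compound 2 `CC(C)c1ccc(NC(=O)OCC2CCCN(Cc3ccccc3)C2)cc1` reaches only the limit of the assay, > 100000 nM.
Compound 3 `C#CCN1CCCC(COC(=O)N(C)CC)C1` likewise reaches only the limit of the assay, > 100000 nM.

Compound 3 therefore stands at the weak end of this small set, where no number but only a limit is known; the same is true of compound 2, as the limit of > 100000 nM in this assay, at which 2 of the 3 values shown sit, records. The not yet measured compound 4 `CCN(C)C(=O)OCC1CCCN(Cc2ccccc2)C1` differs from compound 3 in one place: phenyl in place of ethynyl on a saturated chain carbon bound to an amine nitrogen in a ring. For the measured compounds named here, no step between two measured compounds covers this exchange, so the size of its effect is open. Compound 1 and compound 2 both carry the benzyl group, and neither is strong. The step from compound 3 to compound 4 is expected to stay within the scatter, an at least 1.2-fold lower number from compound 3 to compound 4 (0.09 log units; that floor lies within the scatter), so compound 4 is estimated at 80000 nM, between 20000 nM and 320000 nM.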

Compound 4, half-maximal inhibitory concentration: > 100000 nM
Compound 4 ended at the assay's limit (the forecaster's own chance of this, stated with the estimate: 60%); middle value at least 1.2-fold (0.09 log units) away from the limit.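

Compound 3 and compound 4 both end at a limit rather than a number, so no step between them can be read: the limit of > 100000 nM in this assay, at which 3 of the 4 values shown sit.

The compounds shown leave open whether phenyl in place of ethynyl changes inhibition at all.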